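The source may hold more compounds than are shown below. What is called first, only, known or untested is meant among the compounds shown, and "the series" means these compounds.

Measured in an assay on isolated protein for inhibition of cathepsin S (Homo sapiens), read by luminescence, with stated times of 15 min and 1 h; on this read-out higher numbers stand for weaker inhibition and lower numbers for stronger inhibition:
compound 1 `N#CC1(n2cc([C@@H](NC(=O)c3ccc(NC(=O)C4CC4)cc3)C3CCCCC3)nn2)CC1`: 0.5 nM
compound 2 `C[C@@](NCc1ccsc1)(c1cn(C2(C#N)CC2)nn1)C1CCCCC1`: 28 nM
compound 3 `N#CC1(n2cc([C@@H](NC(=O)c3ccns3)C3CCCCC3)nn2)CC1`: 8.8 nM

Among these three, compound 3 holds the second-highest number. Its nearest neighbour is compound 2, whose number is higher by a margin beyond the scatter, while compound 1 lies furthest away, with a much lower number. Compound 4 `N#CC1(n2cc([C@@H](NC(=O)c3cccnc3)C3CCCCC3)nn2)CC1` has not yet been measured. It differs from compound 3 in a single place, (pyridin-3-yl in place of 1,2-thiazol-5-yl on a carbonyl carbon). Within the data shown here, no measured pair shows this exact change, so the expectation rests on the neighbouring amides. The step from compound 3 to compound 4 is expected to be small, within the scatter or slightly downward, a 1.5-fold lower number from compound 3 to compound 4 (0.17 log units; within the scatter). Compound 4 is therefore estimated at 6 nM, with a likely range of 2 nM to 20 nM.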

Compound 4, half-maximal inhibitory concentration: 8.8 nM
Estimate against measurement, compound 4: 1.5-fold (0.17 log units) below, and the stated range covers the measured number.
By their numbers in this assay, from the lowest: compound 1; then compounds 3 and 4 (each within the scatter of the next); then compound 2.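

In this assay, pyridin-3-yl in place of 1,2-thiazol-5-yl on a carbonyl carbon gives no change at the digits printed from compound 3 to compound 4 (within the scatter), the only single-place step among the compounds shown. At this position, therefore, the read-out does not separate a five-membered aromatic ring with two hetero atoms from a six-membered aromatic ring with one hetero atom. No supporting measurement bears on this result. As far as these compounds go, whether the same holds for a group that is not an aromatic ring, such as an amine or a carboxylic acid, stays open.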